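The compounds below may be only part of what the source reports. "The series", "measured", "known", "first", "only" and "open" are said of these compounds alone.

Compound 3 `C[C@H](NC(=O)Nc1cccc(F)c1)c1ccccc1` gives 94% in an ADME assay on the whole organism with Oryza sativa as the target, tested at 1 uM; on this read-out lower numbers stand for a stronger effect and higher numbers for a weaker effect at the one concentration tested. Among the three compounds measured, its number is the second highest. Its nearest neighbour is compound 2 `CCOC(=O)c1cccc(NC(=O)N[C@@H](C)c2ccccc2)c1`, which in this assay gives 99%; the step of a number 5 percentage points lower from compound 2 to compound 3 (within the scatter) is within the scatter. The furthest is compound 1 `CC(C)c1cccc(NC(=O)N[C@@H](C)c2ccccc2)c1`, which in this assay gives 84%; the step of a number 10 percentage points higher from compound 1 to compound 3 (within the scatter) is likewise within the scatter, whereas the step of a number 15 percentage points higher from compound 1 to compound 2 (beyond the scatter) is beyond it. Compound 4 `C[C@H](NC(=O)Nc1cccc(Cl)c1)c1ccccc1` differs from compound 3 in one place: chloro in place of fluoro on an aromatic carbon. The two steps that bear on this change are those at the same aromatic carbon, from isopropyl and from ethoxycarbonyl to fluoro, and neither of them moved the number beyond the scatter. A swap of one halogen for another at that carbon is therefore expected to give a step of a number 2 percentage points lower from compound 3 to compound 4 (within the scatter) in this assay, which is no step beyond the scatter. For compound 4 the number in this assay is estimated at 92%, with a range from 80% to 100%.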

Compound 4, a percentage reported as activity, at one concentration (the size of the read-out at that concentration, not a potency): 99%
For compound 4 the middle estimate is 7 percentage points below the measured one; the measured number falls inside the stated range.
By their numbers in this assay, from the lowest: compounds 1, 3, 2 and 4 (each within the scatter of the next, the first and the last beyond it).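

In this assay the swap of one halogen for the other at this aromatic carbon gives a number 5 percentage points higher from compound 3 to compound 4 (within the scatter) and so does not separate chloro from fluoro, and chloro is likewise not separated from ethoxycarbonyl by the step of no change at the digits printed from compound 2 to compound 4 (within the scatter) at the same carbon. Isopropyl now stands apart from chloro through a number 15 percentage points higher from compound 1 to compound 4 (beyond the scatter) as well as from ethoxycarbonyl through a number 15 percentage points higher from compound 1 to compound 2 (beyond the scatter) in this assay, while the step of a number 10 percentage points higher from compound 1 to compound 3 (within the scatter) leaves it unseparated from fluoro. Nothing available gives a reason for these steps.

From the compounds shown here alone, what an amine, a carboxylic acid or a longer chain would give at this carbon remains open. Also open, going by these compounds, is whether the swap of chloro for fluoro would give a similar step at another carbon of the ring.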